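The source may report more compounds than this note shows. Statements on the series, on what has been measured and on what is new or still open speak of the compounds shown alone.

Compound 1 `O=C(c1ccc(C(=O)C(F)(F)F)cc1)N1CCOc2ccc(-c3cnc4ccccc4c3)cc2C1` and compound 2 `O=C(c1ccc(C(=O)C(F)(F)F)cc1)N1CCOc2ccc(-c3ccc4nc[nH]c4c3)cc2C1` differ in one place. In an ADME assay on MDCK cells (Canis lupus familiaris) for permeability (a higher number here means that the compound crosses the layer faster, a lower number that the compound crosses the layer more slowly), compound 1 gives 16.9 nm/s and compound 2 gives 9.8 nm/s. These two numbers lie within the scatter of each other, so compound 2 cannot be ranked against compound 1. Compound 3 `NS(=O)(=O)c1ccc(C(=O)N2CCOc3ccc(-c4ccc5nc[nH]c5c4)cc3C2)cc1` keeps the rest of compound 2 and carries sulfamoyl in place of (trifluoromethyl)carbonyl on an aromatic carbon. Going by the values given here, the only measured step, a 1.7-fold lower number from compound 1 to compound 2 (0.24 log units; within the scatter), involves a different group in a different place, so it bears on this exchange only indirectly. Among the compounds with values here, no measured step covers the exchange itself, and the range must stay wide. The expected step is small, a 1.4-fold lower number from compound 2 to compound 3 (0.15 log units; within the scatter), with no change beyond the scatter expected. For compound 3 the estimated value is 7 nm/s, with an expected range from 2.5 nm/s to 20 nm/s.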

Compound 3, apparent permeability: 42 nm/s
Compound 3: middle estimate off by 6.0-fold (0.78 log units), on the low side; measured number outside the range, above it.
By their numbers in this assay, from the lowest: compounds 2 and 1 (each within the scatter of the next); then compound 3.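

At this position, on an aromatic carbon para to a large group, the choice of group can move the number in this assay: sulfamoyl in place of (trifluoromethyl)carbonyl gives a 4.3-fold higher number from compound 2 to compound 3 (0.63 log units; beyond the scatter), whereas the earlier change at a different place, a 1.7-fold lower number from compound 1 to compound 2 (0.24 log units; within the scatter), stayed within the scatter. Sulfamoyl has 4 heavy atoms and 1 hydrogen-bond donor, against 6 heavy atoms and 0 hydrogen-bond donors for (trifluoromethyl)carbonyl, but one exchange cannot show which of these differences, if any, goes with the higher number. Nothing measured here explains the step.

On these data alone, whether the same exchange gives a similar step with the quinolin-3-yl of compound 1 remains open. So does how a carboxylic acid, an amine or a nitrile at this position would compare with sulfamoyl.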